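Aminomethyl next to the ring nitrogen: outlook for compound 3

The compounds below may be only part of what the source reports. "The series", "measured", "known", "first", "only" and "open" are said of these compounds alone.

Measured so far in an assay on HEK293 cells for binding affinity to adenosine receptor A3 (Homo sapiens), read by NanoBRET; on this read-out higher numbers stand for weaker binding and lower numbers for tighter binding:
compound 1, `COc1cc(Nc2nc(Cl)cc3c(-c4ccccc4)n[nH]c23)cc(OC)c1OC`, 85.1 nM
compound 2, `COc1cc(Nc2nccc3c(-c4ccccc4)n[nH]c23)cc(OC)c1OC`, 74.1 nM

For the measured compounds named here, compound 2 and compound 1 sit within the usual scatter of each other; the only measured step, a 1.1-fold lower number from compound 1 to compound 2 (0.06 log units; within the scatter), does not separate them, so compound 2 holds no distinct place on these two numbers.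

The next compound, compound 3, is `COc1cc(Nc2nc(CN)cc3c(-c4ccccc4)n[nH]c23)cc(OC)c1OC`. Relative to compound 2 the change is aminomethyl in place of hydrogen on an aromatic carbon. The group enters on an aromatic carbon of a six-membered aromatic ring with one nitrogen, part of a fused system of two rings, next to the ring nitrogen, meta to a fused ring, meta to a large group and para to a fused ring.

Only a 1.1-fold lower number from compound 1 to compound 2 (0.06 log units; within the scatter) bears on this position, and it involved a different group and stayed within the scatter. It gives no guide to aminomethyl, so for this assay no step beyond the scatter is expected in either direction; the expected step is a 1.2-fold higher number from compound 2 to compound 3 (0.08 log units; within the scatter). Compound 3 is expected at 90 nM, with a range from 30 nM to 300 nM.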

Compound 3, dissociation constant: 257 nM
Estimate against measurement, compound 3: 2.9-fold (0.46 log units) below; measured number inside the range.
By their numbers in this assay, from the lowest: compounds 2 and 1 (each within the scatter of the next); then compound 3.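

In this assay, this aromatic carbon next to the ring nitrogen turns out not to be indifferent to its substituent: aminomethyl gives a 3.5-fold higher number from compound 2 to compound 3 (0.54 log units; beyond the scatter) when it replaces hydrogen, and a 3.0-fold higher number from compound 1 to compound 3 (0.48 log units; beyond the scatter) when it replaces chloro. Hydrogen and chloro did not separate at this position, so compound 3 gives the first step beyond the scatter here, and both of its steps point the same way, towards weaker binding. The size of both steps is modest, so binding is reduced by this change without being lost, but nothing available gives a reason for the shift.

The compounds shown do not tell whether the shift follows the amine nitrogen or the added carbon, and a methyl or hydroxymethyl group on the same carbon would bear directly on that question. Also open, on these data alone, is how far the trend extends with a longer chain such as aminoethyl, a substituted amine such as dimethylaminomethyl, or a carboxylic acid, and whether any of these would stay close to compound 2 or move further in the direction of compound 3.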